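The source may hold more compounds than are shown below. What is called first, only, known or untested is meant among the compounds shown, and "the series" means these compounds.

In an ADME assay on cells (Hepatocyte, Mus musculus) for metabolic stability, read by LC-MS, tested at 1 uM (on this read-out higher numbers stand for a longer-lived compound and lower numbers for a shorter-lived compound), compound 2 (`CCOC(=O)NC(=O)c1ccsc1NC(=O)c1ccc(S(=O)(=O)N2CCCC2)cc1`) gives 0.495 h, the higher of the two numbers available. Among the compounds with values here, the only other measured compound, compound 1 (`Cc1ccnc(NC(=O)c2ccsc2NC(=O)c2ccc(S(=O)(=O)N3CCCCC3)cc2)n1`), gives 0.132 h, and the gap between them lies beyond the usual scatter. Compound 3 (`CCOC(=O)NC(=O)c1ccsc1NC(=O)c1ccc(S(=O)(=O)N2CCCCC2)cc1`) has not yet been measured. It departs from compound 2 in a single place: piperidin-1-yl in place of pyrrolidin-1-yl on a sulfonyl sulfur, which puts piperidin-1-yl in place of pyrrolidin-1-yl on a sulfonyl sulfur. Within the data shown here, no measured pair shows this change on its own, so the expectation is only loosely supported. It rests on compound 1, which also carries piperidin-1-yl and gives the lower 0.132 h, though it differs elsewhere too. The expected change is a 1.5-fold lower number from compound 2 to compound 3 (0.18 log units; within the scatter), a small downward step that probably stays within the scatter. For compound 3 the estimated half-life is 0.33 h, with an expected range of 0.15 h to 0.7 h.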

Compound 3, half-life: 0.843 h
For compound 3 the middle estimate is 2.6-fold (0.41 log units) below the measured one, outside the stated range (above it).
By their numbers in this assay, from the lowest: compound 1; then compounds 2 and 3 (each within the scatter of the next).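

In this assay, within the data shown here, the first pair showing this change on its own, with ethoxycarbonyl held in place, gives a 1.7-fold higher number from compound 2 to compound 3 (0.23 log units; within the scatter) and so does not separate piperidin-1-yl from pyrrolidin-1-yl on a sulfonyl sulfur. Among these compounds, the low number of compound 1 therefore does not follow piperidin-1-yl: with that group held, ethoxycarbonyl in place of 4-methylpyrimidin-2-yl on an amide-type nitrogen gives a 6.4-fold higher number from compound 1 to compound 3 (0.81 log units; beyond the scatter) and is the only one of these two steps beyond the scatter. Nothing available gives a reason for either step.

The compounds shown leave open whether a morpholin-4-yl or dimethylamino group on the sulfonyl sulfur would behave like these two rings. They also leave open whether an acetyl or methoxycarbonyl group on the amide-type nitrogen would match ethoxycarbonyl.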